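The source may report more compounds than this note shows. Statements on the series, on what has been measured and on what is new or still open speak of the compounds shown alone.

Compound 1, `CCOc1ccc(NC(=O)c2cccc(/C=C3\CC(=O)N(Cc4ccccc4)C3=O)c2)cc1`, in an ADME assay on NCM460 cells (Homo sapiens) for cytotoxicity, read by MTT assay, with a stated time of 72 h (a higher number here means a weaker inhibitor, a lower number a stronger inhibitor), gives > 100000 nM, which is a limit of the assay rather than a number.
Compound 2, `COc1ccc(OC)c(NC(=O)c2cccc(/C=C3\CC(=O)N(c4ccccc4)C3=O)c2)c1`, in this assay gives > 100000 nM, again a limit of the assay.
Compound 3, `O=C(Nc1ccccc1)c1cccc(/C=C2\CC(=O)N(c3ccccc3)C2=O)c1`, in this assay gives > 100000 nM, also a limit of the assay.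

So compound 3 stands where every measured compound stands: at a limit, with no number attached. The only measured step between two of these compounds, a step that the two limits leave unreadable from compound 2 to compound 3, cannot be read in size, since both ends are limits. The move from compound 3 to compound 4, `O=C(Nc1ccc(Cl)cc1)c1cccc(/C=C2\CC(=O)N(c3ccccc3)C2=O)c1`, is a small one: chloro in place of hydrogen on an aromatic carbon. Within the data shown here, no measured step gives a direction for a chloro entering on an aromatic carbon. What the data do give is the limit of > 100000 nM in this assay, at which 3 of the 3 values shown sit, and that is the whole basis for any expectation here. On that basis, compound 4 is expected to sit in the same place, so the step that the limit leaves unreadable from compound 3 to compound 4 is expected to be none beyond the scatter. For compound 4 in this assay the estimate is 150000 nM, within 50000 nM to 500000 nM, most likely reported only as a limit.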

Compound 4, half-maximal inhibitory concentration: > 100000 nM
Compound 4 ended at the assay's limit (the forecaster's own chance of this, stated with the estimate: 85%); the middle value does not contradict the limit.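

Compound 4 also gives a limit of the assay rather than a number, so the steps to it from compound 2 and compound 3 cannot be read in size: the limit of > 100000 nM in this assay, at which 4 of the 4 values shown sit.

The compounds shown leave open what structural change, if any, would give a measurable value in this assay.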